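Clearance notes: aryl amide variation on the shared core

A few compounds are considered here, and "the series" means these few. Any claim that something is new, unique, unknown or untested is made for them only; others in the source may bear on it.

Measured so far in an in vitro ADME assay on microsomes from liver (Mus musculus) for pharmacokinetics, read by LC-MS, with a stated time of 10 min, tested at 1 uM; a higher number here means faster removal of the compound, a lower number slower removal:
- compound 1 `CN1C[C@H](C(=O)Nc2ccc(C#N)cc2)[C@@H](c2ccc(/C=C/C(=O)Nc3ccccc3N)cc2)C1` gives 35 mL/min/kg
- compound 2 `CN1C[C@H](C(=O)Nc2ccc(C3CC3)cc2)[C@@H](c2ccc(/C=C/C(=O)Nc3ccccc3N)cc2)C1` gives 60 mL/min/kg
- compound 3 `CN1C[C@H](C(=O)Nc2ccc(Br)cc2)[C@@H](c2ccc(/C=C/C(=O)Nc3ccccc3N)cc2)C1` gives 16 mL/min/kg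

Compound 2 stands at the highest number of the three in this assay. Its nearest neighbour is compound 1, and the step of a 1.7-fold higher number from compound 1 to compound 2 (0.23 log units; within the scatter) lies within the scatter, so no order between those two is claimed. The step to compound 3, a 3.8-fold lower number from compound 2 to compound 3 (0.57 log units; beyond the scatter), is beyond the scatter, as is a 2.2-fold lower number from compound 1 to compound 3 (0.34 log units; beyond the scatter).

The next compound, compound 4 `CN1C[C@H](C(=O)Nc2ccc(F)c(Cl)c2)[C@@H](c2ccc(/C=C/C(=O)Nc3ccccc3N)cc2)C1`, differs from compound 2 as follows: 3-chloro-4-fluorophenyl in place of 4-cyclopropylphenyl on an amide-type nitrogen. The halogen-bearing measured step is the one that bears most on this: bromo in place of cyclopropyl gave a 3.8-fold lower number from compound 2 to compound 3 (0.57 log units; beyond the scatter). Bromo in place of cyano gave a 2.2-fold lower number from compound 1 to compound 3 (0.34 log units; beyond the scatter). Within the data shown here, a moderately lower number is therefore expected for compound 4, though no measured compound carries two halogens on that ring, so the estimate is uncertain.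

Compound 4 is estimated at 25 mL/min/kg in this assay, with a range from 10 mL/min/kg to 55 mL/min/kg, because the change to compound 3 gave a 3.8-fold lower number from compound 2 to compound 3 (0.57 log units; beyond the scatter). This estimate means an expected step of a 2.4-fold lower number from compound 2 to compound 4 (0.38 log units; beyond the scatter).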

Compound 4, clearance: 34 mL/min/kg
Compound 4: middle estimate off by 1.4-fold (0.13 log units), on the low side; the measured number falls inside the stated range.
By their numbers in this assay, from the lowest: compound 3; then compounds 4, 1 and 2 (each within the scatter of the next).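

In this assay, the 3-chloro-4-fluorophenyl group on the amide-type nitrogen is not separated from the 4-cyclopropylphenyl group, with a 1.8-fold lower number from compound 2 to compound 4 (0.25 log units; within the scatter), or from the 4-cyanophenyl group, with a 1.0-fold lower number from compound 1 to compound 4 (0.01 log units; within the scatter). It is separated from the 4-bromophenyl group, with a 2.1-fold higher number from compound 3 to compound 4 (0.33 log units; beyond the scatter), which shows that a halogen-bearing ring at this position does not by itself place a compound with compound 3 at the low end; among the compounds shown, compound 4 goes against any such reading. Nothing at hand explains these differences.

Open, as far as these compounds go, is what chloro and fluoro each contribute, which a phenyl ring carrying only one of them would separate. Also open, from the compounds shown here alone, is how an amine or a carboxylic acid on this ring would read in this assay.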